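A few compounds are considered here, and "the series" means these few. Any claim that something is new, unique, unknown or untested is made for them only; others in the source may bear on it.

Measured in a functional assay on HepG2 cells (Homo sapiens) for inhibition, read by MTT assay, with a stated time of 48 h; a lower number here means a stronger inhibitor, a higher number a weaker inhibitor:
compound 1 `COc1ccc(N(C)c2nc(C)nc3ccccc23)cc1[Se]C` gives 17 nM
compound 2 `Cc1nc(N(C)c2ccc([Se]C#N)c(Cl)c2)c2ccccc2n1` gives 12 nM

For the measured compounds named here, the two numbers lie within the scatter of each other, so compound 1 stands level with the only other measured compound. Compound 3 `COc1ccc(N(C)c2nc(C)nc3ccccc23)cc1C[Se]C#N` differs from compound 1 by a group of 4 heavy atoms (2 carbon, 1 nitrogen, 1 selenium; no ring) in place of a group of 2 heavy atoms (1 carbon, 1 selenium; no ring), on an aromatic carbon on an aromatic carbon, ortho to a methoxy group. Going by the values given here, no measured step covers this change, so no shift beyond the scatter is expected in either direction. The expected move is a 1.1-fold lower number from compound 1 to compound 3 (0.05 log units; within the scatter) and rests on compound 1 alone. Compound 3 is estimated at 15 nM (range 5 nM to 50 nM) in this assay for now.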

Compound 3, half-maximal inhibitory concentration: 1110 nM
For compound 3 the middle estimate is 74-fold (1.87 log units) below the measured one; measured number outside the range, above it.
By their numbers in this assay, from the lowest: compounds 2 and 1 (each within the scatter of the next); then compound 3.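

At the aromatic carbon ortho to a methoxy group, the substituent clearly matters: in this assay, the group of 4 heavy atoms in place of the group of 2 heavy atoms gives a 65-fold higher number from compound 1 to compound 3 (1.81 log units; beyond the scatter). For the compounds shown here, this is the first change that can be read at a single place, and it shows that this position does not accept every selenium-bearing group equally. No measured evidence bears on the reason for the loss.

The step changes the group's length and adds a triple bond together, so their contributions remain unseparated. Going by these compounds, how an amine or a longer carbon chain at this position would read also remains open.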